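Dimethylamino in Place of Trifluoromethyl: What to Expect

The source may hold more compounds than are shown below. What is called first, only, known or untested is meant among the compounds shown, and "the series" means these compounds.

Of the compounds shown here, two have been measured so far in an assay on isolated protein for displacement of a labelled ligand from secreted frizzled-related protein 1 (Homo sapiens), read by fluorescence polarization, with a stated time of 30 min; on this read-out higher numbers stand for weaker inhibition and lower numbers for stronger inhibition. Compound 1 `O=C(c1cccc(Cl)c1)N1CCC(NS(=O)(=O)c2cc(S(=O)(=O)c3ccccc3)ccc2C(F)(F)F)CC1` gives 300 nM in this assay. Compound 2 `O=C(c1ccc(C(F)(F)F)cc1)N1CCC(NS(=O)(=O)c2cc(S(=O)(=O)c3ccccc3)ccc2C(F)(F)F)CC1` gives 400 nM in this assay. Compound 2 holds the higher of the two numbers, yet the step from compound 1 to compound 2 is only a 1.3-fold higher number from compound 1 to compound 2 (0.12 log units; within the scatter), which falls within the scatter, so the two compounds cannot be told apart on this read-out. That one step replaces 3-chlorophenyl with 4-(trifluoromethyl)phenyl on a carbonyl carbon.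

Compound 3 `CN(C)c1ccc(C(=O)N2CCC(NS(=O)(=O)c3cc(S(=O)(=O)c4ccccc4)ccc3C(F)(F)F)CC2)cc1` has not yet been measured. It differs from compound 2 by dimethylamino in place of trifluoromethyl on an aromatic carbon. For the measured compounds named here, the only measured step, from compound 1 to compound 2, changes a group on the same ring and was within the scatter; no measured pair involves a dimethylamino group, so the data give no direction for this change. The expected step is therefore no change at the digits printed from compound 2 to compound 3 (within the scatter), nothing beyond the scatter. Compound 3 is estimated at 400 nM, with a range from 150 nM to 1200 nM.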

Compound 3, half-maximal inhibitory concentration: 300 nM
For compound 3 the middle estimate is 1.3-fold (0.12 log units) above the measured one; measured number inside the range.
By their numbers in this assay, from the lowest: compounds 1, 3 and 2 (each within the scatter of the next).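

At the ring carbon para to a large group, dimethylamino and trifluoromethyl cannot be told apart in this assay (a 1.3-fold lower number from compound 2 to compound 3 (0.12 log units; within the scatter)), even though this swap replaces a group of carbon and fluorine with one containing nitrogen and adds a hydrogen-bond acceptor to the count. The 4-(dimethylamino)phenyl and 3-chlorophenyl compounds also match (no change at the digits printed from compound 1 to compound 3 (within the scatter)), so all three aryl groups shown on this carbonyl carbon now give numbers within the scatter of one another, and none of these swaps has a measurable effect on the read-out. No measurement at hand speaks to why these numbers stay so close.

The compounds shown leave open whether this position would stay just as undemanding with a carboxylic acid, a primary amine or a longer alkyl chain on the same aromatic carbon, any of which might finally produce a step beyond the scatter. They also share the rest of their structure, so they reveal nothing about how much the shared core contributes to the numbers seen here.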